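From 4-fluorophenyl to 4-methoxyphenyl in the series

The compounds below may be only part of what the source reports. "The series", "measured", "known", "first", "only" and "open" are said of these compounds alone.

In a functional assay on HCT-116 cells (Homo sapiens) for antiproliferative activity, read by MTT assay, with a stated time of 72 h (on this read-out lower numbers stand for stronger inhibition and higher numbers for weaker inhibition), compound 1 (`COc1ccc(/C=C2\S/C(=N\c3ccc(C)c(Cl)c3)N(C)C2=O)cc1`) gives 14100 nM and compound 2 (`COc1ccc(/C=C2\S/C(=N\c3ccc(F)cc3)N(C)C2=O)cc1`) gives 13300 nM as its reading, so compound 2 stands level with compound 1 within the scatter. Compound 3 (`COc1ccc(/C=C2\S/C(=N\c3ccc(OC)cc3)N(C)C2=O)cc1`) carries methoxy in place of fluoro on an aromatic carbon, para to a large group (methoxy in place of fluoro on an aromatic carbon). Within the data shown here, one measured step bears on this: a 1.1-fold lower number from compound 1 to compound 2 (0.03 log units; within the scatter), with 4-fluorophenyl in place of 3-chloro-4-methylphenyl. Among the measured compounds shown here, no measured compound shows what methoxy does at this place, so that single small step is the only guide and the range stays wide. The expected step (a 1.1-fold higher number from compound 2 to compound 3 (0.02 log units; within the scatter)) is estimated to stay within the scatter, with no direction favoured in this assay. Compound 3 is expected at about 14000 nM, with an estimated range from 6000 nM to 32000 nM in this read-out.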

Compound 3, half-maximal inhibitory concentration: > 100000 nM
Compound 3: a limit, no number (the forecaster's own chance of this, stated with the estimate: 5%); at least 7.1-fold (0.85 log units) between middle value and limit.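

In this assay compound 3 gives > 100000 nM, which is a limit of the assay and not a number. The phenyl on the double-bonded nitrogen is thus not indifferent to its substituent: compound 1 and compound 2 stand level within the scatter, yet methoxy in place of fluoro, para to a large group, gives an at least 7.5-fold higher number from compound 2 to compound 3 (0.87 log units; beyond the scatter), and 4-methoxyphenyl in place of 3-chloro-4-methylphenyl gives an at least 7.0-fold higher number from compound 1 to compound 3 (0.85 log units; beyond the scatter). This single change at this place therefore moves the reading beyond the scatter, and the true size of the step stays unknown, since only a limit is available: the limit of > 100000 nM in this assay, at which 1 of the 3 values shown sits.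

The compounds shown leave open whether this weakening is specific to methoxy or extends to other groups at this place, such as hydroxy, ethoxy or an amine. They also leave open whether a group smaller than methoxy but larger than fluoro, such as methyl, keeps the reading of compound 2.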